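A few compounds are considered here, and "the series" means these few. Any claim that something is new, unique, unknown or untested is made for them only; others in the source may bear on it.

Measured compounds in a functional assay on A549 cells (Homo sapiens) for inhibition, read by MTT assay, with a stated time of 72 h; a lower number here means a stronger inhibitor, a higher number a weaker inhibitor:

Compound 1 `CCOc1ccc(C2CC2C(=O)NNC(=O)c2ccncc2)cc1`: 43000 nM
Compound 2 `O=C(NNc1nncc2ccccc12)C1CC1c1ccc(OCC(F)(F)F)cc1`: 48000 nM
Compound 3 `O=C(NNc1nncc2ccccc12)C1CC1c1ccc(OC(F)(F)F)cc1`: 87000 nM

Of these three numbers, compound 1 gives the lowest. Compound 2 lies within the usual scatter of it, so the two cannot be ranked against each other; compound 3 gives a number that is higher than compound 1 by more than the scatter, which is the one clear separation among the three.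

Compound 4 `CC(C)=CCOc1ccc(C2CC2C(=O)NNC(=O)c2ccncc2)cc1` is built from compound 1 by one change: 2-methylprop-1-en-1-yl in place of methyl on a saturated chain carbon bound to an oxygen on an aromatic ring. For the measured compounds named here, the only measured step that touches the same region, the group on the aromatic oxygen, is a 1.8-fold higher number from compound 2 to compound 3 (0.26 log units; within the scatter). That step sits on a different core and swaps a different pair of groups, so it is only loosely comparable, but it shows that altering the group on that oxygen left the number within the scatter. Going by the values given here, no measured pair shows the effect of lengthening this chain on the core of compound 1.

On that basis, the step of a 1.2-fold lower number from compound 1 to compound 4 (0.09 log units; within the scatter) is expected to stay within the scatter, with no confident direction. Compound 4 is therefore estimated at 35000 nM, with a plausible range from 12000 nM to 100000 nM.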

Compound 4, half-maximal inhibitory concentration: > 100000 nM
Compound 4 was reported as a limit; the forecaster's own chance of this, stated with the estimate: 10%; middle value at least 2.8-fold (0.45 log units) from the limit.
By their numbers in this assay, from the lowest: compounds 1, 2 and 3 (each within the scatter of the next, the first and the last beyond it). At a limit, above all of these: compound 4.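

In this assay, for the compounds shown here, exchanging ethoxy for (3-methylbut-2-en-1-yl)oxy on the shared core gives an at least 2.3-fold higher number from compound 1 to compound 4 (0.36 log units; beyond the scatter), and this is the first step on the group at the aromatic oxygen that lies beyond the scatter. The earlier step at that oxygen, a 1.8-fold higher number from compound 2 to compound 3 (0.26 log units; within the scatter), stayed within the scatter on a different core, and it gave no sign that the number could respond to the group carried there. Compound 4 stands at a limit of the assay rather than at a number, and the full size of its step cannot be read: the limit of > 100000 nM in this assay, at which 1 of the 4 values shown sits.

Going by these compounds, whether the larger number goes with the added chain length or with the double bond remains open, and a saturated 3-methylbutoxy group or a shorter propoxy chain on the core of compound 1 would be needed to tell these apart. Also open, on these data alone, is how the trifluoromethoxy and 2,2,2-trifluoroethoxy groups of compound 3 and compound 2 would behave on the core of compound 1, since those two compounds differ from it in more than one place.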